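A few compounds are considered here, and "the series" means these few. Any claim that something is new, unique, unknown or untested is made for them only; others in the source may bear on it.

Of the compounds shown here, three of one family have been tested in an ADME assay on HEK293 cells (Homo sapiens) for cytotoxicity, read by MTT assay, with a stated time of 44 h; a higher number here means a weaker inhibitor, a lower number a stronger inhibitor. Compound 1, `Cc1ccc(C2ON=C(c3ccccc3Cl)O2)cc1`, is the parent. In this assay compound 1 gives a limit rather than a number, > 100000 nM. Compound 2, `CCc1ccc(C2ON=C(c3ccccc3Cl)O2)cc1`, carries methyl in place of hydrogen on a saturated chain carbon bound to an aromatic carbon. In this assay compound 2 also gives only a limit, > 100000 nM. The step that the two limits leave unreadable from compound 1 to compound 2 is therefore not readable in size.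

Compound 3, `CC1(c2cccc(Br)c2)ON=C(c2ccc(Cl)cc2)O1`, is built on a different core; the difference between the two cores is not broken down here. In this assay compound 3 gives a limit as well, > 100000 nM. The common thread is the limit of > 100000 nM in this assay, at which 3 of the 3 values shown sit.

Compound 4, `CCC1(c2cccc(Br)c2)ON=C(c2ccc(Cl)cc2)O1`, has not yet been measured. It differs from compound 3 by methyl in place of hydrogen on a saturated chain carbon bound to a saturated ring carbon. This is the same kind of change as that from compound 1 to compound 2, though the place differs: there the carbon is bound to an aromatic carbon, here to a saturated ring carbon. Given that every value shown sits at the limit, compound 4 is expected to stay there too, and its value in this assay is estimated at 200000 nM, a step that the limit leaves unreadable from compound 3 to compound 4.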

Compound 4, half-maximal inhibitory concentration: > 100000 nM
Compound 4 gave a limit, no number (the forecaster's own chance of this, stated with the estimate: 85%); the middle value is on the limit's open side.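

Compound 3 and compound 4 each give only a limit in this assay, so no size can be read for the step between them, and one shared finding remains: the limit of > 100000 nM in this assay, at which 4 of the 4 values shown sit. The compounds shown leave open how far any of them lies past that limit, and whether any change in this family would give a readable number.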